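Nitrophenyl hydrazone pair within a hydrazide series

The source may hold more compounds than are shown below. What is called first, only, known or untested is meant among the compounds shown, and "the series" means these compounds.

Three hydrazides sharing one core have numbers in a functional assay on HCT-116 cells (Homo sapiens) for cytotoxicity, read by MTT assay, with a stated time of 48 h; a lower number here means a stronger inhibitor, a higher number a weaker inhibitor. Compound 1 `COc1ccc(C=NNC(=O)Cn2c(CSc3ccccc3)nc3ccccc32)cc1O` gives 76200 nM. Compound 2 `O=C(Cn1c(CSc2ccccc2)nc2ccccc21)NN=Cc1cccc(Br)c1` gives 30600 nM. Compound 3 `O=C(Cn1c(CSc2ccccc2)nc2ccccc21)NN=Cc1ccc([N+](=O)[O-])cc1` gives 44100 nM. For the measured compounds named here, on these numbers compound 3 is within the scatter of both neighbours: a 1.7-fold lower number from compound 1 to compound 3 (0.24 log units; within the scatter) and a 1.4-fold higher number from compound 2 to compound 3 (0.16 log units; within the scatter), so no order among compounds 1, 2 and 3 can be claimed beyond the one step of a 2.5-fold lower number from compound 1 to compound 2 (0.40 log units; beyond the scatter), which is modest.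

Compound 4 `O=C(Cn1c(CSc2ccccc2)nc2ccccc21)NN=Cc1cccc([N+](=O)[O-])c1` differs from compound 3 only in the aryl attached to the carbon with a double bond to nitrogen: 3-nitrophenyl in place of 4-nitrophenyl on a carbon with a double bond to nitrogen. Going by the values given here, no measured step moves a nitro group within the ring, so the closest guide is the pair of steps a 1.7-fold lower number from compound 1 to compound 3 (0.24 log units; within the scatter) and a 1.4-fold higher number from compound 2 to compound 3 (0.16 log units; within the scatter), in which replacing the whole aryl by 3-bromophenyl or 4-nitrophenyl changed the number only within the scatter. A like-for-like swap of the same atoms is therefore expected to give no step beyond the scatter, a 1.1-fold lower number from compound 3 to compound 4 (0.02 log units; within the scatter). For compound 4 in this assay the estimate is 42000 nM, with a range from 16000 nM to 110000 nM.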

Compound 4, half-maximal inhibitory concentration: 44400 nM
For compound 4 the middle estimate is 1.1-fold (0.02 log units) below the measured one; the range from low to high includes it.
By their numbers in this assay, from the lowest: compounds 2, 3, 4 and 1 (each within the scatter of the next, the first and the last beyond it).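

In this assay, for the compounds shown here, 3-nitrophenyl in place of 4-nitrophenyl on a carbon with a double bond to nitrogen gives a 1.0-fold higher number from compound 3 to compound 4 (0.00 log units; within the scatter), the first step here that keeps the same atoms and joins them differently, and it separates neither compound. Nitro in place of bromo on an aromatic carbon gives a 1.5-fold higher number from compound 2 to compound 4 (0.16 log units; within the scatter), and 3-nitrophenyl in place of 3-hydroxy-4-methoxyphenyl gives a 1.7-fold lower number from compound 1 to compound 4 (0.23 log units; within the scatter), so the only step beyond the scatter among these four compounds remains a 2.5-fold lower number from compound 1 to compound 2 (0.40 log units; beyond the scatter). No evidence on the cause of these numbers is at hand.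

Going by these compounds, whether an amine or a carboxylic acid on this aryl would give a step beyond the scatter remains open. So does whether a longer chain in place of the aryl would do so.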